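The compounds below may be only part of what the source reports. "The series", "measured", "known", "first", "only" and "open" are said of these compounds alone.

Of the compounds shown here, three built on one shared core have been tested in a functional assay on the whole organism (strain CD1) with Mus musculus as the target, in the maximal electroshock model, with a stated time of 0.5 h; on this read-out higher numbers stand for an effect only at larger amounts of compound and lower numbers for an effect already at smaller amounts. Compound 3 `CC1CC(=O)N(CC(=O)N2CCN(c3ccc(Cl)c(Cl)c3)CC2)C1=O` gives 300 mg/kg in this assay. Compound 1 `Cc1ccccc1N1CCN(C(=O)CN2C(=O)CC(C)C2=O)CC1` gives 300 mg/kg, and compound 2 `Cc1cccc(N2CCN(C(=O)CN3C(=O)CC(C)C3=O)CC2)c1` gives 300 mg/kg. These three differ only in the aromatic group attached to an amine nitrogen in a ring, and the measured steps are all flat: no change at the digits printed from compound 1 to compound 2 (within the scatter), no change at the digits printed from compound 1 to compound 3 (within the scatter) and no change at the digits printed from compound 2 to compound 3 (within the scatter). So compound 3 stands level with compounds 1 and 2, and no one of the three can be called more or less active than another.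

Compound 4 `CC1CC(=O)N(CC(=O)N2CCN(c3ccc(F)cc3)CC2)C1=O` is the next member. Its change from compound 3 is 4-fluorophenyl in place of 3,4-dichlorophenyl on an amine nitrogen in a ring. The steps measured so far all swap one aromatic group for another at this same place, and none of them moved the minimum effective dose beyond the scatter. On that basis the swap to 4-fluorophenyl is expected to behave alike, with no change at the digits printed from compound 3 to compound 4 (within the scatter) as the expected step, that is, no change beyond the scatter.

Compound 4 is therefore estimated at 300 mg/kg in this assay, with an expected range from 100 mg/kg to 600 mg/kg.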

Compound 4, minimum effective dose: 300 mg/kg
For compound 4 middle estimate and measured number coincide at the digits printed; the range from low to high includes it.
By their numbers in this assay, from the lowest: compounds 1, 2, 3 and 4 (each within the scatter of the next).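

In this assay, within the data shown here, the swap of 3,4-dichlorophenyl for 4-fluorophenyl gives no change at the digits printed from compound 3 to compound 4 (within the scatter) and so extends the flat picture to a phenyl ring carrying a single fluorine, a halogen pattern that the earlier compounds did not include. The methyl-bearing groups compare the same way, with no change at the digits printed from compound 2 to compound 4 (within the scatter) and no change at the digits printed from compound 1 to compound 4 (within the scatter) as the two further steps, so all four aromatic groups on this amine nitrogen in a ring now stand level in this read-out. Nothing available explains why these groups behave alike.

The compounds shown leave open whether an amine or a carboxylic acid on the phenyl ring, or a longer chain in place of the aromatic group on this nitrogen, would move the minimum effective dose in either direction. All four compounds also share the same remaining structure, so they say nothing about how a change elsewhere in the shared core would act.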